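A few compounds are considered here, and "the series" means these few. Any claim that something is new, unique, unknown or untested is made for them only; others in the source may bear on it.

Measured so far in a functional assay on HCT-116 cells (Homo sapiens) for antiproliferative activity, read by radiometric assay, with a stated time of 72 h (a higher number here means a weaker inhibitor, a lower number a stronger inhibitor), are these values
compound 1 (`Cc1ccccc1Nc1ncnc2cc(NC(=O)CCCCCCC(=O)NO)sc12`) at 2560 nM
compound 2 (`O=C(CCCCCCC(=O)Nc1cc2ncnc(Nc3ccc(Cl)cc3F)c2s1)NO`) at 1790 nM
compound 3 (`Cc1ccc(F)c(Nc2ncnc3cc(NC(=O)CCCCCCC(=O)NO)sc23)c1`) at 1330 nM

Compound 3 is not separated from the other two, with a 1.9-fold lower number from compound 1 to compound 3 (0.28 log units; within the scatter) and a 1.3-fold lower number from compound 2 to compound 3 (0.13 log units; within the scatter) as the steps that reach it. The next structure is compound 4 (`COc1ccc(Nc2ncnc3cc(NC(=O)CCCCCCC(=O)NO)sc23)cc1`), which has 4-methoxyphenyl in place of 2-fluoro-5-methylphenyl on a nitrogen on an aromatic ring. All measured steps exchange the group at this same place. Besides the two above, the third is a 1.4-fold lower number from compound 1 to compound 2 (0.16 log units; within the scatter) and it too is small. Among the measured compounds shown here, none of the measured compounds carries 4-methoxyphenyl, so the entering group itself is untested. With only these small steps as a guide, no step beyond the scatter is expected in this assay and no direction can be called. The estimated step is a 1.4-fold higher number from compound 3 to compound 4 (0.13 log units; within the scatter) for this change. Compound 4 is expected at 1800 nM with 800 nM to 4000 nM as the estimated range.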

Compound 4, half-maximal inhibitory concentration: 2180 nM
Compound 4: the middle estimate sits 1.2-fold (0.08 log units) below what was measured; the measured number falls inside the stated range.
By their numbers in this assay, from the lowest: compounds 3, 2, 4 and 1 (each within the scatter of the next).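

In this assay, exchanging 2-fluoro-5-methylphenyl, with no hydrogen-bond acceptor, for 4-methoxyphenyl, with one, gives a 1.6-fold higher number from compound 3 to compound 4 (0.21 log units; within the scatter), and the other two steps to the same group are a 1.2-fold higher number from compound 2 to compound 4 (0.09 log units; within the scatter) and a 1.2-fold lower number from compound 1 to compound 4 (0.07 log units; within the scatter). The entering group, previously untested at this place, therefore does not separate compound 4 from compound 1, compound 2 or compound 3, and all four compounds now stand within the scatter of one another. No evidence at hand bears on this result.

Still open, on these data alone, is whether a group on the nitrogen other than these four substituted phenyl rings, such as an aminophenyl, a carboxyphenyl or a pyridyl ring, would give a step beyond the scatter. Also open, as far as these compounds go, is whether a change elsewhere, such as a longer chain on the amide, would shift the number.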